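Swapping the cyano group for methoxy on a dihydropyridine

The compounds below may be only part of what the source reports. "The series", "measured", "known", "first", "only" and "open" are said of these compounds alone.

Compound 1 `COC(=O)C1=C(C)N=C(C)/C(=C(\O)OC)C1c1ccccc1C#N` gives 15.9 nM in a functional assay (muscle tissue) with Cavia porcellus as the target; a higher number here means that more compound is needed for the effect, a lower number that less compound is needed.
Compound 3 `COC(=O)C1=C(C)N=C(C)/C(=C(\O)OC)C1c1ccccc1Br` gives 7.59 nM in this assay.
Compound 2 `COC(=O)C1=C(C)N=C(C)/C(=C(\O)OC)C1c1cc(OC)c(OC)cc1OC` gives 1000000 nM in this assay.

Among these three numbers compound 1 stands second highest: compound 3 needs a 2.1-fold lower number from compound 1 to compound 3 (0.32 log units; beyond the scatter), a modest step, while compound 2, carrying a trimethoxyphenyl group, lies enormously higher, far outside any scatter.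

Compound 4 `COC(=O)C1=C(C)N=C(C)/C(=C(\O)OC)C1c1ccccc1OC` keeps the shared core of compound 1 and changes only the group on the aromatic ring: methoxy in place of cyano on an aromatic carbon. For the measured compounds named here, no measured step touches methoxy itself. The step from compound 1 to compound 3 shows that exchanging the group at this place for bromo moves the number only modestly. Going by the values given here, the only methoxy-bearing compound, compound 2, carries three such groups and is essentially inactive, which is not the same change and offers no direct guide.

Taken together, a single methoxy at this place is expected to cost some potency relative to compound 1, though far less than the trimethoxy pattern of compound 2 suggests. Compound 4 is therefore expected to give 120 nM, with a range from 20 nM to 800 nM. That estimate means an expected step of a 7.5-fold higher number from compound 1 to compound 4 (0.88 log units; beyond the scatter).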

Compound 4, half-maximal effective concentration: 57.5 nM
The estimate for compound 4 lay 2.1-fold (0.32 log units) above the measured number, and the stated range covers the measured number.
By their numbers in this assay, from the lowest: compound 3; then compound 1; then compound 4; then compound 2.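

In this assay, replacing the cyano group with a single methoxy gives a 3.6-fold higher number from compound 1 to compound 4 (0.56 log units; beyond the scatter), and replacing bromo with methoxy gives a 7.6-fold higher number from compound 3 to compound 4 (0.88 log units; beyond the scatter), so this place tolerates a methoxy group with only a modest step from either neighbour. With three single-group changes now available at this aromatic carbon, the groups fall into an order in which bromo has the lowest number, cyano the middle one and methoxy the highest, with all the steps between them beyond the scatter. Nothing here gives a measured property that would account for this order, so the numbers describe the change without explaining it.

For the compounds shown here, compound 2 differs from compound 4 in more than one place, so what its other methoxy groups contribute remains open, and no single step connects the two compounds. Going by these compounds, it also remains open where an amine, a carboxylic acid or a longer chain such as ethoxy would fall in this order at the same place, and whether methoxy would behave the same way elsewhere on the aromatic ring.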